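A few compounds are considered here, and "the series" means these few. Any claim that something is new, unique, unknown or untested is made for them only; others in the source may bear on it.

In a functional assay on HL-60 cells (Homo sapiens) for inhibition, read by MTT assay, with a stated time of 72 h (on this read-out higher numbers stand for weaker inhibition and lower numbers for stronger inhibition), the series opens with compound 1, `Cc1nc(-c2ccccc2)c(C(=O)N2CCN(c3ccccc3Cl)CC2)o1`, which gives 124 nM. Compound 2, `Cc1nc(-c2ccccc2)c(C(=O)N2CCN(c3ccc(C)c(C)c3)CC2)o1`, gives 43 nM, and compound 3, `Cc1cc(C)cc(N2CCN(C(=O)c3oc(C)nc3-c3ccccc3)CC2)c1`, gives 34.5 nM. Across these three numbers compound 3 has the lowest, but its nearest neighbour is compound 2, and the step of a 1.2-fold lower number from compound 2 to compound 3 (0.10 log units; within the scatter) lies within the scatter, so the two cannot be ordered. The larger moves both start from compound 1: a 2.9-fold lower number from compound 1 to compound 2 (0.46 log units; beyond the scatter) and a 3.6-fold lower number from compound 1 to compound 3 (0.56 log units; beyond the scatter), each modest and beyond the scatter, and both arising from an exchange of the aryl group on the amine nitrogen in the ring.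

Compound 4, `CC(=O)Nc1cccc(N2CCN(C(=O)c3oc(C)nc3-c3ccccc3)CC2)c1`, is the next member to be measured. It differs from compound 3 in a single place: 3-acetamidophenyl in place of 3,5-dimethylphenyl on an amine nitrogen in a ring. For the measured compounds named here, no measured step swaps a dimethylphenyl for an acetamidophenyl, so nothing bears on this change directly. The measured steps only show that exchanges of the aryl group at this position have shifted the number modestly, while a rearrangement of the same substituents left it unmoved. The step is therefore expected to be small, with no clear direction, and compound 4 is expected to give about 60 nM, between 20 nM and 200 nM, an expected step of a 1.7-fold higher number from compound 3 to compound 4 (0.24 log units; within the scatter).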

Compound 4, half-maximal inhibitory concentration: 329 nM
The estimate for compound 4 lay 5.5-fold (0.74 log units) below the measured number; the measured number lies above the stated range.
By their numbers in this assay, from the lowest: compounds 3 and 2 (each within the scatter of the next); then compound 1; then compound 4.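

In this assay, the group on the amine nitrogen in the ring proves able to move the number much further than the earlier exchanges did: a 9.5-fold higher number from compound 3 to compound 4 (0.98 log units; beyond the scatter) and a 7.7-fold higher number from compound 2 to compound 4 (0.88 log units; beyond the scatter). The 3-acetamidophenyl group also falls behind the 2-chlorophenyl group, with a 2.7-fold higher number from compound 1 to compound 4 (0.42 log units; beyond the scatter), so among the four compounds this change alone gives a number above that of compound 1. Nothing available explains this rise.

The entering group differs from 3,5-dimethylphenyl in several ways at once, bringing a nitrogen, an oxygen, a hydrogen-bond donor, a hydrogen-bond acceptor and a double bond outside the aromatic ring, and the compounds shown do not separate these features from one another. Going by these compounds, it remains open whether a 3-aminophenyl group, with a plain amine in place of the acetamide, or a 3-methoxyphenyl group, with an ether oxygen and no amide hydrogen, would stay near compound 3 or rise towards compound 4.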